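This account rests on a few compounds, and the source may have more. Where it says the series, first, only, none or still open, it means among the compounds named here.

Measured so far in a functional assay on cells (T-cell, Homo sapiens) for inhibition; a lower number here means a stronger inhibitor, a higher number a weaker inhibitor:

compound 1, `COc1ccc(-c2cnc3nc(N)nc(N4CCN(c5cc(Cl)cc(Cl)c5)CC4)c3n2)cc1OC`, gives 3400 nM
compound 2, `COc1ccc(-c2cnc3nc(N)nc(N4CCN(C(=O)Nc5ccc(C#N)cc5)CC4)c3n2)cc1OC`, gives 74 nM
compound 3, `COc1ccc(-c2cnc3nc(N)nc(N4CCN(C(=O)COc5ccc(Cl)cc5)CC4)c3n2)cc1OC`, gives 0.5 nM

Compound 3 holds the lowest number of the three. Its nearest neighbour is compound 2, and the step was a 150-fold lower number from compound 2 to compound 3 (2.17 log units; beyond the scatter); the furthest is compound 1, with a 6800-fold lower number from compound 1 to compound 3 (3.83 log units; beyond the scatter).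

The next compound is compound 4, `COc1ccc(-c2cnc3nc(N)nc(N4CCN(C(=O)Nc5ccc(F)cc5)CC4)c3n2)cc1OC`. Its difference from compound 3 is (4-fluorophenyl)amino in place of (4-chlorophenoxy)methyl on a carbonyl carbon.

Going by the values given here, only one measured step speaks to this change: compound 2 carries a (4-cyanophenyl)amino group on the same carbonyl carbon, and replacing it by (4-chlorophenoxy)methyl gave a 150-fold lower number from compound 2 to compound 3 (2.17 log units; beyond the scatter). Compound 4 walks that step back, with a (4-fluorophenyl)amino group in place of the (4-cyanophenyl)amino of compound 2, so a large rise in this assay is expected. For compound 4 the expected step is a 100-fold higher number from compound 3 to compound 4 (2.00 log units; beyond the scatter). Compound 4 is estimated at 50 nM, with a range from 10 nM to 300 nM.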

Compound 4, half-maximal inhibitory concentration: 7 nM
The estimate for compound 4 lay 7.1-fold (0.85 log units) above the measured number; measured number outside the range, below it.
By their numbers in this assay, from the lowest: compound 3; then compound 4; then compound 2; then compound 1.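

Compound 4 shows that the aromatic substituent matters here even with the (4-…)amino link on the carbonyl carbon left unchanged: fluoro in place of cyano gives an 11-fold lower number from compound 2 to compound 4 (1.02 log units; beyond the scatter) in this assay as a large step. The (4-chlorophenoxy)methyl group still keeps a large lead, with a 14-fold higher number from compound 3 to compound 4 (1.15 log units; beyond the scatter) as the step, so a (4-fluorophenyl)amino group narrows the gap without closing it, and a 490-fold lower number from compound 1 to compound 4 (2.69 log units; beyond the scatter) places this carbonyl-linked group far ahead of 3,5-dichlorophenyl on the ring nitrogen. No measurement shown here explains these differences.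

From the compounds shown here alone, the step from compound 3 to compound 4 swaps the link and the halogen together, so their separate shares remain unknown; a (4-fluorophenoxy)methyl group would pull them apart. Going by these compounds, how a methoxy or a methyl group in place of the fluoro would behave also stays open.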